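Reversing the Amide: From Compound 3 to Compound 4

The source may report more compounds than this note shows. Statements on the series, on what has been measured and on what is new or still open speak of the compounds shown alone.

Three measured compounds share one core. In an assay on CHO-K1 cells for displacement of a labelled ligand from prostaglandin E2 receptor EP1 subtype (Homo sapiens) (a higher number here means a weaker inhibitor, a lower number a stronger inhibitor), compound 1 `CNC(=O)c1cc(C)n(Cc2cc(Cl)ccc2OCc2ccccc2)n1` gives 100 nM, compound 2 `Cc1cc(C(=O)Nc2ccccc2)nn1Cc1cc(Cl)ccc1OCc1ccccc1` gives 39.8 nM, and compound 3 `Cc1cc(C(=O)NCc2ccccc2)nn1Cc1cc(Cl)ccc1OCc1ccccc1` gives 39.8 nM. Compound 3 sits level with compound 2, and the two together give the lowest numbers; the step of a 2.5-fold lower number from compound 1 to compound 3 (0.40 log units; beyond the scatter) is modest, while no change at the digits printed from compound 2 to compound 3 (within the scatter). Compound 4 `Cc1cc(NC(=O)CC(C)(C)C)nn1Cc1cc(Cl)ccc1OCc1ccccc1` carries (neopentylcarbonyl)amino in place of benzylcarbamoyl on an aromatic carbon. For the measured compounds named here, no measured step tests this change directly: a 2.5-fold lower number from compound 1 to compound 2 (0.40 log units; beyond the scatter) and a 2.5-fold lower number from compound 1 to compound 3 (0.40 log units; beyond the scatter) concern only what hangs on the amide nitrogen, and the aromatic ring that both of them added is now gone. In this assay a modest rise in the number is therefore expected, a 6.3-fold higher number from compound 3 to compound 4 (0.80 log units; beyond the scatter). Compound 4 is estimated at 250 nM, within 60 nM to 1000 nM.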

Compound 4, half-maximal inhibitory concentration: 10 nM
Estimate against measurement, compound 4: 25-fold (1.40 log units) above, and the stated range ends above it.
By their numbers in this assay, from the lowest: compound 4; then compounds 2 and 3 (each within the scatter of the next); then compound 1.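

The ring carried by the earlier amides is not needed at this position: (neopentylcarbonyl)amino, which has no ring, gives a lower number than benzylcarbamoyl (a 4.0-fold lower number from compound 3 to compound 4 (0.60 log units; beyond the scatter)). The comparisons with phenylcarbamoyl (a 4.0-fold lower number from compound 2 to compound 4 (0.60 log units; beyond the scatter)) and methylcarbamoyl (a 10-fold lower number from compound 1 to compound 4 (1.00 log units; beyond the scatter)) point the same way, placing this open-chain, reversed amide ahead of all three earlier amides. No supporting measurement explains the gain.

As far as these compounds go, compound 4 changes the amide's direction and its chain together, and their separate shares remain unknown. A reversed amide carrying benzyl, or a shorter chain such as ethyl, could begin to separate them.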